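Thiourea series on glioblastoma cells: a nitrile replaces a methoxy

The source may hold more compounds than are shown below. What is called first, only, known or untested is meant among the compounds shown, and "the series" means these compounds.

Measured so far:
compound 1 `COc1ccccc1NC(=S)NC1CC(C)(C)Oc2ccc(Br)cc21`, 42000 nM
compound 2 `CC1(C)CC(NC(=S)Nc2ccc([N+](=O)[O-])cc2)c2cc(F)ccc2O1`, 5000 nM

Both compounds were tested in a functional assay on T98G cells (Homo sapiens) for inhibition, read by MTT assay, with a stated time of 72 h; on this read-out lower numbers stand for stronger inhibition and higher numbers for weaker inhibition. Compound 1 has the higher of the two numbers; compound 2 lies well below it, a gap that is beyond the scatter of this assay. The two differ in more than one place, so their values alone cannot be traced to a single group.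

The next compound, compound 3 `CC1(C)CC(NC(=S)Nc2cccc(C#N)c2)c2cc(Br)ccc2O1`, has not yet been measured. It is derived from compound 1 by one change: 3-cyanophenyl in place of 2-methoxyphenyl on an amide-type nitrogen. Among the measured compounds shown here, compound 2 shows that a substituted phenyl other than 2-methoxyphenyl on this nitrogen can go with a much lower number, at 5000 nM, but that compound also carries a different halogen on the core, so the present step has no direct precedent. A modest improvement is expected, roughly a 3.5-fold lower number from compound 1 to compound 3 (0.54 log units; beyond the scatter) in this assay, with wide uncertainty. Compound 3 is therefore estimated at 12000 nM, in a range from 4000 nM to 40000 nM.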

Compound 3, half-maximal inhibitory concentration: 9000 nM
Estimate against measurement, compound 3: 1.3-fold (0.12 log units) above, and the stated range covers the measured number.
By their numbers in this assay, from the lowest: compounds 2 and 3 (each within the scatter of the next); then compound 1.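

In this assay, putting 3-cyanophenyl in place of 2-methoxyphenyl on the amide-type nitrogen, whose other neighbour is the thiocarbonyl carbon, gives a 4.7-fold lower number from compound 1 to compound 3 (0.67 log units; beyond the scatter), a modest step. Among the compounds shown here, this is the first comparison here in which the shared core stays the same and only the group on this nitrogen changes, so the difference can be traced to this one place, which the pair of compound 1 and compound 2 could not show. What lies behind the step cannot be said, as no measurement bearing on the two groups is available.

The single step swaps methoxy for nitrile and also alters the numbering of the substituent on the phenyl, so the compounds shown do not separate the identity of the group from its place. Nor do they show how an unsubstituted phenyl, or a phenyl carrying an amine or a carboxylic acid, would read on this nitrogen with the core of compound 3 held constant.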